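Pyrrolidinyl ketone replacing pentafluorophenyl in a growth-inhibition series

This account rests on a few compounds, and the source may have more. Where it says the series, first, only, none or still open, it means among the compounds named here.

Measured compounds:
compound 1, `O=C(/C(=C\c1ccc([N+](=O)[O-])c(O)c1)SCc1ccc(Br)cc1)c1c(F)c(F)c(F)c(F)c1F`, 10000 nM
compound 2, `CSc1ccc(/C=C(\C(=O)c2ccc(Br)cc2)S(=O)(=O)Cc2ccc(C)cc2)cc1`, 10000 nM
compound 3, `O=C(/C(=C\c1ccc([N+](=O)[O-])c(O)c1)Sc1ccc(Br)cc1)c1c(F)c(F)c(F)c(F)c1F`, 1000 nM

In a functional assay on DU-145 cells (Homo sapiens) for inhibition, read by trypan blue exclusion, with a stated time of 96 h (a higher number here means a weaker inhibitor of growth, a lower number a stronger inhibitor of growth), compound 1 gives 10000 nM. It is level with compound 2 at the digits shown, and together they stand at the highest number of the three. Among the measured compounds shown here, the only compound that separates from them is compound 3, which in this assay gives 1000 nM; that step, a 10-fold lower number from compound 1 to compound 3 (1.00 log units; beyond the scatter), is modest and lies beyond the scatter.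

Compound 4, `O=C(/C(=C\c1ccc([N+](=O)[O-])c(O)c1)SCc1ccc(Br)cc1)C1CCNC1`, is not yet measured. It differs from compound 1 at the carbonyl carbon: pyrrolidin-3-yl in place of 2,3,4,5,6-pentafluorophenyl on a carbonyl carbon. For the measured compounds named here, none of the measured steps concerns this part of the shared core; the single step that is known, from compound 1 to compound 3, changes the group on the sulfur and leaves the carbonyl side untouched. Going by the values given here, with no step bearing on the change, the expectation for compound 4 is a step of no size beyond the scatter, no change at the digits printed from compound 1 to compound 4 (within the scatter). Compound 4 is therefore estimated at 10000 nM, within a range from 3000 nM to 30000 nM.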

Compound 4, concentration for 50% growth inhibition: > 100000 nM
Compound 4: no number, only a limit (the forecaster's own chance of this, stated with the estimate: 30%); middle value at least 10-fold (1.00 log units) away from the limit.
By their numbers in this assay, from the lowest: compound 3; then compounds 1 and 2 (each within the scatter of the next). At a limit, above all of these: compound 4.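

In this assay, among the compounds shown here, the earlier compounds showed only the group on the sulfur moving the number, but the carbonyl side of the shared core matters as well: pyrrolidin-3-yl in place of 2,3,4,5,6-pentafluorophenyl on a carbonyl carbon gives an at least 10-fold higher number from compound 1 to compound 4 (1.00 log units; beyond the scatter). This step runs in the opposite direction to the one seen on the sulfur, so this position tolerates this exchange poorly in this assay. For compound 4 the reading is a limit and not a number, so the step has a lower bound but no measured size: the limit of > 100000 nM in this assay, at which 1 of the 4 values shown sits.

The exchange alters the ring, its atoms and the hydrogen-bond count all at once, and the compounds shown do not separate these. From the compounds shown here alone, whether a plain phenyl, a cyclopentyl or a piperidine on the same carbonyl carbon would stay level with compound 1 remains open, as does the outcome of pairing pyrrolidin-3-yl with the 4-bromophenyl on a sulfur.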